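The source may hold more compounds than are shown below. What is called first, only, known or untested is meant among the compounds shown, and "the series" means these compounds.

Measured so far in an assay on isolated protein for inhibition of AP2-associated protein kinase 1 (Homo sapiens), with a stated time of 3 h, in the presence of a further agent that is not named here; on this read-out lower numbers stand for stronger inhibition and higher numbers for weaker inhibition:
compound 1 `COC(=O)Nc1cc(-c2cnc(OC[C@@](C)(N)CC(C)C)c(Cl)c2)ccn1` 0.4 nM
compound 2 `COC(=O)Nc1cc(-c2ccc(OC[C@@](C)(N)CC(C)C)nc2)ccn1` 28 nM
compound 3 `COC(=O)Nc1cc(-c2cnc(OC[C@@](C)(N)CC(C)C)c(C#N)c2)ccn1` 1 nM

Compound 2 stands highest of the three in this assay. Its partners differ from it by a single group on the shared core: the step of a 70-fold higher number from compound 1 to compound 2 (1.85 log units; beyond the scatter), read in the direction from compound 2 back to compound 1, and the step of a 28-fold lower number from compound 2 to compound 3 (1.45 log units; beyond the scatter) show that adding chloro or cyano lowers the number strongly. Compound 4 `COC(=O)Nc1cc(-c2cnc(OC[C@@](C)(N)CC(C)C)cc2C)ccn1` instead carries methyl in place of hydrogen on an aromatic carbon. The large measured steps concern a different substituent than methyl, so they only suggest that a group on this ring can matter much. A smaller gain is expected here, a 1.9-fold lower number from compound 2 to compound 4 (0.27 log units; within the scatter), giving an estimated 15 nM for compound 4 in this assay, within 2 nM to 120 nM.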

Compound 4, half-maximal inhibitory concentration: 490 nM
Compound 4: the middle estimate sits 33-fold (1.51 log units) below what was measured; the measured number lies above the stated range.
By their numbers in this assay, from the lowest: compound 1; then compound 3; then compound 2; then compound 4.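

In this assay, a single methyl on this aromatic carbon, ortho to a large group and opposite the ring nitrogen, is enough to weaken inhibition sharply: an 18-fold higher number from compound 2 to compound 4 (1.24 log units; beyond the scatter). Adding a group to this ring can therefore move the number either way, since the chloro and cyano of compound 1 and compound 3 sit on a different carbon and lower it. Nothing available explains why this methyl raises the number. Still open, from the compounds shown here alone, is whether fluoro or methoxy on this same carbon would also raise it, or whether the rise is particular to methyl.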